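The source may report more compounds than this note shows. Statements on the series, on what has been measured and on what is new or still open speak of the compounds shown alone.

In a functional assay on MCF7 cells (Homo sapiens) for inhibition, read by CCK-8 assay, with a stated time of 48 h (on this read-out lower numbers stand for stronger inhibition and higher numbers for weaker inhibition), compound 1 `COc1cc(-c2ccnc3cc(-c4cn(CO)c5ccccc45)nn23)cc(OC)c1OC` gives 19 nM and compound 2 `COc1cc(-c2ccnc3cc(-c4c[nH]c5ccccc45)nn23)cc(OC)c1OC` gives 85 nM, the higher of the two numbers. Compound 3 `COc1cc(-c2ccnc3cc(-c4ccc(C)c(C)c4)nn23)cc(OC)c1OC` carries 3,4-dimethylphenyl in place of 1H-indol-3-yl on an aromatic carbon. Within the data shown here, only one measured step bears on this, a 4.5-fold higher number from compound 1 to compound 2 (0.65 log units; beyond the scatter), and it changes just the group on an aromatic nitrogen of the part that now leaves. It does not test the swap itself, so a modest rise of similar size or somewhat larger is expected, estimated as a 2.6-fold higher number from compound 2 to compound 3 (0.41 log units; beyond the scatter). For compound 3 the expected value is 220 nM, with an estimated range of 50 nM to 1200 nM.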

Compound 3, half-maximal inhibitory concentration: 26 nM
Beside the measured number, compound 3's estimate is 8.5-fold (0.93 log units) above it; measured number below the stated range.
By their numbers in this assay, from the lowest: compounds 1 and 3 (each within the scatter of the next); then compound 2.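

In this assay, the swap of 1H-indol-3-yl for 3,4-dimethylphenyl on this aromatic carbon gives a 3.3-fold lower number from compound 2 to compound 3 (0.51 log units; beyond the scatter) and so shows that the position accepts a six-membered aromatic ring of carbon only, with no hydrogen-bond donor, and that the number still falls. No evidence here explains this step. The compounds shown leave open whether the drop follows from the two methyl groups or from the phenyl ring itself, and how an unsubstituted phenyl, a 4-methoxyphenyl or a pyridine ring would read at this carbon.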